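Amide aryl variation on the tosyl-benzylamine scaffold

The source may report more compounds than this note shows. Statements on the series, on what has been measured and on what is new or still open speak of the compounds shown alone.

Compound 2 `Cc1ccc(C(=O)NCc2ccc(CNS(=O)(=O)c3ccc(C)cc3)cc2)cc1` gives 1000 nM in an assay on MDA-MB-231 cells for binding affinity to C-X-C chemokine receptor type 4 (Homo sapiens), read by immunofluorescence and microscopy, with stated times of 10 min and 30 min (on this read-out higher numbers stand for an effect only at larger amounts of compound and lower numbers for an effect already at smaller amounts), the highest of the three numbers in hand. Compound 1 `Cc1ccc(S(=O)(=O)NCc2ccc(CNC(=O)c3ccncc3)cc2)cc1` gives 10 nM, and compound 3 `O=C(NCc1ccc(CNS(=O)(=O)c2ccccc2)cc1)c1c(Cl)cc(Cl)cc1Cl` gives 10 nM. Going by the values given here, the one single-point step available is a 100-fold higher number from compound 1 to compound 2 (2.00 log units; beyond the scatter); it shows that the aryl group on the carbonyl carbon moves the read-out strongly. Among the compounds with values here, compound 3 differs from compound 2 in more than one place, so no step is drawn between them; their two values simply stand two orders apart.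

Compound 4 `Cc1ccc(S(=O)(=O)NCc2ccc(CNC(=O)c3ccccc3F)cc2)cc1` is the next entry. Relative to compound 2 the change is 2-fluorophenyl in place of 4-methylphenyl on a carbonyl carbon. Within the data shown here, no measured step covers this exact exchange, so the expectation rests on the shared core and on the observation that the group on the carbonyl carbon has already shifted the number by a 100-fold higher number from compound 1 to compound 2 (2.00 log units; beyond the scatter). Because compound 3, carrying a different aryl on that carbon, gives 10 nM, a lower number than compound 2 is the more likely outcome, though the size is uncertain. The estimated step is a 10-fold lower number from compound 2 to compound 4 (1.00 log units; beyond the scatter). For compound 4 the estimate is 100 nM, expected to fall between 10 nM and 1000 nM.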

Compound 4, effective concentration (reported as EC, without a stated level of effect): 1000 nM
The estimate for compound 4 lay 10-fold (1.00 log units) below the measured number; low and high end bracket the measured number.
By their numbers in this assay, from the lowest: compounds 1 and 3 (each within the scatter of the next); then compounds 2 and 4 (each within the scatter of the next).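

Exchanging 4-methylphenyl for 2-fluorophenyl on the carbonyl carbon gives no change at the digits printed from compound 2 to compound 4 (within the scatter) in this assay, so this position does not tell these two aryl groups apart. The step of a 100-fold higher number from compound 1 to compound 4 (2.00 log units; beyond the scatter) repeats the large gap already seen with compound 2, so pyridin-4-yl now stands apart from two different aryl groups of carbon only, not just one; this pattern covers only compounds 1, 2 and 4, while compound 3, at 10 nM, differs from compound 2 and compound 4 in more than one place and so neither supports nor contradicts it as a step. Nothing measured here explains the gap or the absence of a change between these two aryl groups.

The compounds shown leave open whether pyridin-3-yl or pyridin-2-yl on the carbonyl carbon would group with compound 1 or with compound 2 and compound 4, and where an unsubstituted phenyl or an aminophenyl would fall. They also leave open how much of the value of compound 3 belongs to its amide aryl group and how much to the aryl group on its sulfonyl, a question that only a single-change partner for compound 3 could settle.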